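A few compounds are considered here, and "the series" means these few. Any claim that something is new, unique, unknown or untested is made for them only; others in the source may bear on it.

Measured so far in a functional assay on DU-145 cells (Homo sapiens) for cytotoxicity, read by MTT assay, with a stated time of 72 h; a lower number here means that less compound is needed, a higher number that more compound is needed for the effect:
Compound 1 `CCc1cccc2c(OC)c(-c3occ(C)c3C(=O)OC)ccc12`: 2.2 ug/mL
Compound 2 `CCOc1c(-c2occ(C)c2C(=O)OC)ccc2c(CC)cccc12`: 1.9 ug/mL

Among the compounds with values here, compound 2 stands level with compound 1, the only other measured compound. Within the data shown here, the single measured step is a 1.2-fold lower number from compound 1 to compound 2 (0.06 log units; within the scatter). It is methyl in place of hydrogen on a saturated chain carbon, a different place from the next change, so it offers little guidance here. Compound 3 `CCOc1c(-c2occ(C)c2CO)ccc2c(CC)cccc12` carries hydroxymethyl in place of methoxycarbonyl on an aromatic carbon. With no direct guide, a modest move towards a higher number in this assay is expected, held only loosely: a 1.8-fold higher number from compound 2 to compound 3 (0.27 log units; within the scatter). Compound 3 is estimated at 3.5 ug/mL, with an expected range of 1 ug/mL to 12 ug/mL.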

Compound 3, concentration for half-maximal effect: > 10 ug/mL
Compound 3: no number, only a limit; the forecaster's own chance of this, stated with the estimate: 10%; middle value at least 2.8-fold (0.45 log units) away from the limit.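

Unlike the earlier change on the saturated chain carbon, the change on the aromatic carbon moves the result clearly in this assay: replacing methoxycarbonyl with hydroxymethyl gives an at least 5.2-fold higher number from compound 2 to compound 3 (0.72 log units; beyond the scatter). Compound 3 has only a limit, > 10 ug/mL, not a measured number, so this step has a known minimum but no known size: the limit of > 10 ug/mL in this assay, at which 1 of the 3 values shown sits.

The change alters heavy atoms and hydrogen-bond donors together, so the compounds shown do not separate these differences. They also leave open how a carboxylic acid or an amide on this carbon would read.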